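Adding an Amino Group to a Glutamate Receptor Blocker

The source may hold more compounds than are shown below. What is called first, only, known or untested is meant among the compounds shown, and "the series" means these compounds.

The starting point is compound 1 `Cc1cccc(NC(=O)c2cccc(C)n2)n1`. In an assay on Ltk cells for inhibition of metabotropic glutamate receptor 5 (Homo sapiens), read by fluorescence (a higher number here means a weaker inhibitor, a lower number a stronger inhibitor), compound 1 gives 32 nM. Among the compounds with values here, only one other compound has been measured so far, compound 2 `Cc1cccc(NC(=O)c2cccc(Br)n2)n1`, which in this assay gives 21 nM. Compound 1 stands highest of the two numbers shown, though the gap is a 1.5-fold lower number from compound 1 to compound 2 (0.18 log units; within the scatter), a difference inside the usual scatter, so the two compounds cannot be told apart on this assay.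

The new compound is compound 3 `Cc1cccc(NC(=O)c2nc(C)ccc2N)n1`, not yet measured. It differs from compound 1 by amino in place of hydrogen on an aromatic carbon. The amino group enters on an aromatic carbon of a six-membered aromatic ring with 1 nitrogen, ortho to a large group, two atoms from the ring nitrogen and para to a methyl group.

Within the data shown here, no measured step touches this position. Among the measured compounds shown here, the only step available, a 1.5-fold lower number from compound 1 to compound 2 (0.18 log units; within the scatter), changes a different carbon of the same ring and stayed within the scatter, so it offers no direction for the new group. The expected step is thus a 1.3-fold higher number from compound 1 to compound 3 (0.10 log units; within the scatter), nothing beyond the scatter. Compound 3 is expected to give 40 nM, within the range 12 nM to 130 nM.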

Compound 3, half-maximal inhibitory concentration: 22 nM
Compound 3: the middle estimate sits 1.8-fold (0.26 log units) above what was measured, within the range that was stated.
By their numbers in this assay, from the lowest: compounds 2, 3 and 1 (each within the scatter of the next).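

In this assay, putting amino in place of hydrogen gives a 1.5-fold lower number from compound 1 to compound 3 (0.16 log units; within the scatter), so compound 3 cannot be told apart from compound 1. Within the data shown here, this is the first look at this carbon, the one ortho to a large group, two atoms from the ring nitrogen and para to a methyl group, and it shows that the position can carry a new heavy atom, here a nitrogen bringing 1 hydrogen-bond donor and 1 hydrogen-bond acceptor, with no change in inhibition beyond the scatter. No supporting measurement is available to explain why the amino group leaves the number within the scatter.

A single small group at a single carbon shows only that this one replacement is accepted, and says nothing about how far that acceptance extends. Going by these compounds, whether a methoxy group, a carboxylic acid or a longer chain such as a propyl group could sit on this same carbon and keep the number close to that of compound 1 remains open, as does whether any group here could move it clearly beyond the scatter in either direction.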